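The source may hold more compounds than are shown below. What is called first, only, known or untested is meant among the compounds shown, and "the series" means these compounds.

Measured so far:
Compound 1, `COc1ccc(/C=N/NC(=S)N/N=C2\C(=O)Nc3ccc(C)cc32)cc1O`, in a functional assay on HeLa cells (Homo sapiens) for inhibition, read by MTT assay (a lower number here means a stronger inhibitor, a higher number a weaker inhibitor), gives 2730 nM.
Compound 2, `Cc1ccc2c(c1)/C(=N/NC(=S)N/N=C/c1ccccc1Br)C(=O)N2`, in this assay reaches only a limit of the assay, > 50000 nM.

Two compounds share one core and differ only in the aromatic group attached to a carbon with a double bond to nitrogen. Within the data shown here, the single measured step, an at least 18-fold higher number from compound 1 to compound 2 (1.26 log units; beyond the scatter), is the only guide available: it shows that this position matters, and that the one value for compound 2 is a limit of > 50000 nM in this assay, at which 1 of the 2 values shown sits, rather than a number.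

Compound 3, `Cc1ccc2c(c1)/C(=N/NC(=S)N/N=C/c1ccccn1)C(=O)N2`, is the next member. It differs from compound 2 by pyridin-2-yl in place of 2-bromophenyl on a carbon with a double bond to nitrogen. Among the measured compounds shown here, no measured step covers a pyridin-2-yl group, so the expectation leans on compound 2 alone; the limit for compound 2 leaves its true value open, so any direction in this assay is possible. The step of an at least 1.4-fold lower number from compound 2 to compound 3 (0.15 log units; that floor lies within the scatter) is an estimate only. Compound 3 is expected to give about 35000 nM, within 5000 nM to 100000 nM.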

Compound 3, half-maximal inhibitory concentration: 3150 nM
Estimate against measurement, compound 3: 11-fold (1.05 log units) above; the measured number lies below the stated range.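

Swapping the aromatic group at this position does not have to cost activity: in this assay, the change to pyridin-2-yl gives an at least 15-fold lower number from compound 2 to compound 3 (1.20 log units; beyond the scatter). The loss seen with 2-bromophenyl is therefore not a general result of replacing 3-hydroxy-4-methoxyphenyl on this carbon, and the comparison of the two active groups gives a 1.2-fold higher number from compound 1 to compound 3 (0.06 log units; within the scatter), so a ring without the hydroxy and methoxy groups serves as well here. The step out of compound 2 is only a floor, and its true size stays unknown: the limit of > 50000 nM in this assay, at which 1 of the 3 values shown sits.

From the compounds shown here alone, it remains open whether the ring nitrogen of pyridin-2-yl or simply the absence of bromine matters more, a question that plain phenyl would help to settle. Going by these compounds, how pyridin-3-yl or a non-aromatic cyclohexyl group would behave on this carbon also remains open.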